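Swapping a Cycloheptylmethyl for a Cyanophenylamino Group

The source may report more compounds than this note shows. Statements on the series, on what has been measured and on what is new or still open speak of the compounds shown alone.

Three compounds share one core and were tested in a functional assay on Shh Light II cells (Mus musculus) for inhibition, read by a luciferase reporter; a lower number here means a stronger inhibitor, a higher number a weaker inhibitor. Compound 3 `O=C(CC1CCCCCC1)N1CCC(c2nc(-c3ccc4ccccc4n3)no2)CC1` gives 840 nM. That number is the second highest of the three: compound 1 `C[C@@H]1C[C@H](c2nc(-c3ccc4ccccc4n3)no2)CCN1C(=O)Nc1ccccc1Cl` gives 2400 nM, a weaker result beyond the scatter, while compound 2 `O=C(Nc1ccccc1Cl)N1CCN(c2nc(-c3ccc4ccccc4n3)no2)CC1` gives 140 nM, a stronger result also beyond the scatter. Compound 4 `N#Cc1ccccc1NC(=O)N1CCC(c2nc(-c3ccc4ccccc4n3)no2)CC1` has not been measured; it differs from compound 3 by (2-cyanophenyl)amino in place of cycloheptylmethyl on a carbonyl carbon. Compound 2 likewise bears an amino-linked aromatic ring on its carbonyl carbon and sits well below compound 3, so a step toward stronger inhibition is expected, a 2.8-fold lower number from compound 3 to compound 4 (0.45 log units; beyond the scatter), though compound 1 shows such a group can also sit high. Compound 4 is estimated at 300 nM, with a range from 80 nM to 1200 nM.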

Compound 4, half-maximal inhibitory concentration: 190 nM
Beside the measured number, compound 4's estimate is 1.6-fold (0.20 log units) above it; low and high end bracket the measured number.
By their numbers in this assay, from the lowest: compounds 2 and 4 (each within the scatter of the next); then compound 3; then compound 1.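

In this assay, among these compounds, putting (2-cyanophenyl)amino in place of cycloheptylmethyl on the carbonyl carbon gives a 4.4-fold lower number from compound 3 to compound 4 (0.65 log units; beyond the scatter) and this is the first direct comparison at this position. The step swaps an all-carbon ring group for an aromatic ring carrying a nitrile and linked through an amino nitrogen, and inhibition becomes stronger. Nothing measured here explains the gain.

As far as these compounds go, the nitrile, the aromatic ring and the amino link all change together, so their shares stay open. Phenylamino or cycloheptylamino on the same core would help to separate them.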